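From 2-chlorophenyl to thiophen-2-yl on the shared core

The source may report more compounds than this note shows. Statements on the series, on what has been measured and on what is new or still open speak of the compounds shown alone.

- compound 1 `Cc1ccc(S(=O)(=O)Oc2cccc(/C=C(\C#N)C(=O)Nc3nnc(C)s3)c2)cc1`: 27%
- compound 2 `Cc1ccc(S(=O)(=O)Oc2cccc(/C=C(\C#N)C(=O)Nc3nnc(-c4ccccc4)s3)c2)cc1`: 52%
- compound 3 `Cc1ccc(S(=O)(=O)Oc2cccc(/C=C(\C#N)C(=O)Nc3nnc(-c4ccccc4Cl)s3)c2)cc1`: 55%

Among the three compounds measured in an ADME assay on HEK-293T cells (Homo sapiens) for inhibition, read by CCK-8 assay, with a stated time of 48 h, tested at 20 uM (on this read-out lower numbers stand for less inhibition of growth and higher numbers for more inhibition of growth at the one concentration tested), compound 3 belongs to the upper pair. The record shows a number 3 percentage points higher from compound 2 to compound 3 (within the scatter), and also a number 28 percentage points higher from compound 1 to compound 3 (beyond the scatter).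

Compound 4 `Cc1ccc(S(=O)(=O)Oc2cccc(/C=C(\C#N)C(=O)Nc3nnc(-c4cccs4)s3)c2)cc1` has thiophen-2-yl in place of 2-chlorophenyl on an aromatic carbon.

Two kinds of measured step bear on this change. Replacing methyl with an aromatic ring moved the number by a modest amount, as in a number 25 percentage points higher from compound 1 to compound 2 (beyond the scatter). Adding chloro in place of hydrogen on that ring gave only a number 3 percentage points higher from compound 2 to compound 3 (within the scatter). Among the compounds with values here, compound 4 keeps an aromatic ring at this place, but no measured compound carries thiophen-2-yl, so the comparison is indirect. The expected result is therefore a number 5 percentage points lower from compound 3 to compound 4 (within the scatter), with no real change anticipated. For compound 4 the estimate is 50%, with an expected range of 36% to 64%.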

Compound 4, percent growth inhibition at one concentration: 43%
The estimate for compound 4 lay 7 percentage points above the measured number; the range from low to high includes it.
By their numbers in this assay, from the lowest: compound 1; then compounds 4, 2 and 3 (each within the scatter of the next, the first and the last beyond it).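

In this assay, a five-membered aromatic ring at this carbon does not fully match 2-chlorophenyl: the change gives a number 12 percentage points lower from compound 3 to compound 4 (beyond the scatter) and so reaches beyond the scatter, while the comparison with phenyl gives a number 9 percentage points lower from compound 2 to compound 4 (within the scatter) and stays within it. Thiophen-2-yl still stands clear of methyl, with a number 16 percentage points higher from compound 1 to compound 4 (beyond the scatter), so an aromatic ring of either size at this carbon goes with a higher number than methyl in these compounds. Nothing measured here accounts for where thiophen-2-yl falls among these groups.

Going by these compounds, it remains open whether a furan-2-yl or a pyridin-2-yl ring at this carbon would fall with thiophen-2-yl or with phenyl, and where an open chain such as butyl would fall relative to methyl. On these data alone, it is also open whether a chloro group on the thiophen-2-yl ring would move the number at all.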